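A few compounds are considered here, and "the series" means these few. Any claim that something is new, unique, unknown or untested is made for them only; others in the source may bear on it.

Measured compounds:
Compound 1 `Cc1cc(NCc2nccn2C)n2nc(C)c(-c3ccccc3)c2n1`, in a physicochemical assay for solubility, read by HPLC, using the shake flask method, measured as kinetic solubility, with a stated time of 2 h, at pH 7.4 (on this read-out higher numbers stand for higher solubility and lower numbers for lower solubility), compound 1 gives 26900 nM.
Compound 2 `COc1ccc(-c2c(C)nn3c(NCc4ccccn4)cc(C)nc23)cc1`, for compound 2 only a limit is reported, < 5000 nM.
Compound 3 `Cc1cc(NCc2ccccn2)n2ncc(-c3cccc(Cl)c3)c2n1`, for compound 3 likewise only a limit is reported, < 5000 nM.

Among the measured compounds shown here, compound 3 thus stands at the limit named in the limit of < 5000 nM in this assay, at which 2 of the 3 values shown sit, with no number of its own, and compound 1 is the only compound in the set with a measured solubility.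

Compound 4 `Cc1cc(NCc2ccccn2)n2ncc(C3=CCC(F)(F)CC3)c2n1` is not yet measured. It differs from compound 3 in one place: 4,4-difluorocyclohex-1-en-1-yl in place of 3-chlorophenyl on an aromatic carbon. For the measured compounds named here, no step between two measured compounds is available, so the size of the change from compound 3 to compound 4 in this assay cannot be read from a measured pair. The expectation is a step upward, somewhat beyond the scatter, estimated as an at least 1.8-fold higher number from compound 3 to compound 4 (0.25 log units; that floor lies within the scatter). Compound 4 is estimated at 9000 nM, with a range from 2500 nM to 35000 nM, and a fair chance that this assay again reports only a limit.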

Compound 4, solubility: 5000 nM
Estimate against measurement, compound 4: 1.8-fold (0.26 log units) above; the measured number falls inside the stated range.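

Among the compounds shown here, at the aromatic carbon of the five-membered aromatic ring, 4,4-difluorocyclohex-1-en-1-yl in place of 3-chlorophenyl gives the first single-place comparison, and in this assay it gives a number no lower from compound 3 to compound 4 (the limit leaves the size open). This position therefore accepts a non-aromatic ring of carbon without a drop on this read-out, and compound 4 has a number of its own where compound 3 has only a limit. The size of the step cannot be read, with that limit as the only reference point: the limit of < 5000 nM in this assay, at which 2 of the 4 values shown sit.

This one step exchanges an aromatic ring for a non-aromatic ring and chlorine for fluorine together, so the two changes cannot be told apart. Also open, from the compounds shown here alone, is how a morpholine ring or a carboxylic acid at this carbon would read.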